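A few compounds are considered here, and "the series" means these few. Any claim that something is new, unique, unknown or untested is made for them only; others in the source may bear on it.

Compound 1 `Cc1ccc(S(=O)(=O)N(Nc2ccccc2)C(=O)Oc2ccccc2)cc1` in a functional assay on RAW264.7 cells (Mus musculus), read by immunoassay, with a stated time of 24 h (on this read-out higher numbers stand for weaker inhibition and lower numbers for stronger inhibition), gives 5720 nM. Compound 2 `COc1ccccc1OC(=O)N(Nc1ccccc1)S(=O)(=O)c1ccc(C)cc1` gives 34.1 nM, a step of a 170-fold lower number from compound 1 to compound 2 (2.22 log units; beyond the scatter); the change is methoxy in place of hydrogen on an aromatic carbon. Compound 3 `COc1ccc(S(=O)(=O)N(Nc2ccccc2)C(=O)Oc2ccccc2)cc1` gives 4430 nM, a step of a 1.3-fold lower number from compound 1 to compound 3 (0.11 log units; within the scatter); the two cores differ by methoxy in place of methyl on an aromatic carbon. Compound 4 `COc1ccc(OC(=O)N(Nc2ccccc2)S(=O)(=O)c2ccc(OC)cc2)cc1` is not yet measured and differs from compound 3 by methoxy in place of hydrogen on an aromatic carbon. This is the same kind of change as that made from compound 1 to compound 2, not the same: there the entering methoxy sits ortho to a large group, here para to a large group. Among the measured compounds shown here, the expected step from compound 3 to compound 4 is a 3.0-fold lower number from compound 3 to compound 4 (0.47 log units; beyond the scatter), kept smaller than the earlier one, as the only gain seen, a 170-fold lower number from compound 1 to compound 2 (2.22 log units; beyond the scatter), was made at the ortho placement and no measured pair shows the para placement on this ring. Compound 4 is therefore estimated at 1500 nM, expected within 150 nM to 6000 nM.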

Compound 4, half-maximal inhibitory concentration: 490 nM
Compound 4: middle estimate off by 3.1-fold (0.49 log units), on the high side; measured number inside the range.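

In this assay, methoxy in place of hydrogen lowers the number on both cores, but the size of the step does not carry over: the same change on two cores in this assay, a 170-fold lower number (2.22 log units; beyond the scatter) from compound 1 to compound 2 and a 9.0-fold lower number (0.96 log units; beyond the scatter) from compound 3 to compound 4, 19-fold (1.27 log units) apart, beyond the scatter of two such steps. The new result, a 9.0-fold lower number from compound 3 to compound 4 (0.96 log units; beyond the scatter), supports only the shared direction across these two pairs, and the step from one core does not give the size on the other. The entering methoxy sits para to a large group in compound 4 and at a different place in compound 2, so these pairs cannot separate placement from core.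

Open, on these data alone, is how each placement of methoxy behaves on the other core. Also open, as far as these compounds go, is whether an amine, a carboxylic acid or a longer alkoxy chain at the same place would follow methoxy.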